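This account rests on a few compounds, and the source may have more. Where it says the series, first, only, none or still open, it means among the compounds named here.

Three thiourea analogues carrying a trifluoromethyl-substituted aryl ring have been examined in an ADME assay on MT4 cells (Homo sapiens) for cytotoxicity; a higher number here means that more compound is tolerated, a lower number that less compound is tolerated. Compound 1 `COc1cccc(NC(=S)Nc2cccc(C(F)(F)F)c2)c1` gives 26000 nM in this assay. Compound 2 `CC[C@H]1CC[C@H](c2ccc(NC(=S)Nc3cccc(C(F)(F)F)c3)cc2)CC1` gives 39000 nM, and compound 3 `O=C(NC(=S)Nc1cccc(C(F)(F)F)c1)[C@H]1C[C@@H]2CC[C@H]1C2` gives 42000 nM. Within this set compound 2 stands second highest of the three numbers, but the nearest value, that of compound 3, and the furthest, that of compound 1, are both within the scatter of this assay, so the three compounds cannot be separated on tolerance by these data.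

The step of interest leads from compound 2 to compound 4 `CCCC[C@H]1CC[C@H](c2ccc(NC(=S)Nc3cccc(C(F)(F)F)c3)cc2)CC1`, which has not yet been measured in this assay. The change is ethyl in place of hydrogen on a saturated chain carbon, two bonds along the chain from a saturated ring carbon. Within the data shown here, no measured pair in this set shows a comparable change, so there is no direct precedent for its size or direction. The three measured values lie close together despite their rather different substituents, which suggests that a modest extension of the saturated chain is expected to move the number little; a step no larger than the scatter, a 1.3-fold lower number from compound 2 to compound 4 (0.11 log units; within the scatter), is the working expectation. Compound 4 is therefore estimated at 30000 nM, with a range from 14000 nM to 60000 nM.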

Compound 4, half-maximal cytotoxic concentration: 22000 nM
Compound 4: the middle estimate sits 1.4-fold (0.13 log units) above what was measured; the measured number falls inside the stated range.
By their numbers in this assay, from the lowest: compounds 4, 1, 2 and 3 (each within the scatter of the next).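

In this assay, among these compounds, the change from 4-ethylcyclohexyl to 4-butylcyclohexyl gives the first step that can be read in this set, a 1.8-fold lower number from compound 2 to compound 4 (0.25 log units; within the scatter) and this step lies within the scatter, so compound 2 and compound 4 cannot be told apart on tolerance. At this saturated chain carbon, ethyl in place of hydrogen therefore produces no difference that this read-out can resolve, and each of the four compounds remains within the scatter of the next. No measured evidence bears on why the step is this size.

The compounds shown leave open whether a longer chain, an amine or a carboxylic acid in place of that hydrogen would give a step beyond the scatter. They also leave open whether the same change would behave alike on another core.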